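The source may report more compounds than this note shows. Statements on the series, on what has been measured and on what is new or still open speak of the compounds shown alone.

Compound 2 `COc1cc(-c2cc(C(=O)O)c3ccccc3n2)ccc1OCC(=O)Nc1ccc(F)cc1` stands at the top of the three numbers shown in an ADME assay on HaCaT cells (Homo sapiens) for inhibition (on this read-out lower numbers stand for stronger inhibition and higher numbers for weaker inhibition), with 286000 nM, though its gaps to the other two lie within the scatter. Compound 1 `COc1cc(-c2cc(C(=O)O)c3ccccc3n2)ccc1OCC(=O)Nc1cccc(C)c1` gives 225000 nM in this assay, and compound 3 `COc1cc(-c2cc(C(=O)O)c3ccccc3n2)ccc1OCC(=O)Nc1ccc(C(F)(F)F)cc1` gives 150000 nM. Every step among them is within the scatter: a 1.3-fold higher number from compound 1 to compound 2 (0.10 log units; within the scatter), a 1.5-fold lower number from compound 1 to compound 3 (0.18 log units; within the scatter) and a 1.9-fold lower number from compound 2 to compound 3 (0.28 log units; within the scatter). Compound 4 `CCCCCCNC(=O)COc1ccc(-c2cc(C(=O)O)c3ccccc3n2)cc1OC` has not been measured; it differs from compound 2 in this way: hexyl in place of 4-fluorophenyl on an amide-type nitrogen. Among the compounds with values here, the three measured steps each exchange one aromatic group for another on the amide-type nitrogen, and none of them replaces such a ring with a hexyl chain, so no step bears directly on this change. What they do show is that varied groups on that nitrogen have moved this assay by less than the scatter, so no step beyond the scatter is expected here either. On that footing compound 4 is expected to give 230000 nM, within a range of 100000 nM to 500000 nM. The estimated step is a 1.2-fold lower number from compound 2 to compound 4 (0.09 log units; within the scatter), expected to stay within the scatter.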

Compound 4, half-maximal inhibitory concentration: > 300000 nM
Compound 4 gave a limit, no number; the forecaster's own chance of this, stated with the estimate: 20%; middle value at least 1.3-fold (0.11 log units) away from the limit.
By their numbers in this assay, from the lowest: compounds 3, 1 and 2 (each within the scatter of the next). At a limit, above all of these: compound 4.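

With hexyl in place of an aromatic group on the amide-type nitrogen, compound 4 reaches a limit rather than a number in this assay: the limit of > 300000 nM in this assay, at which 1 of the 4 values shown sits. The steps to it give only floors, an at least 1.0-fold higher number from compound 2 to compound 4 (0.02 log units; that floor lies within the scatter), an at least 1.3-fold higher number from compound 1 to compound 4 (0.12 log units; that floor lies within the scatter) and an at least 2.0-fold higher number from compound 3 to compound 4 (0.30 log units; that floor lies within the scatter), so the limit does not set the chain apart from the aromatic groups beyond the scatter. The position has now held an open chain as well as aromatic groups, and the chain gave no lower number than those groups did.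

The compounds shown leave open the true value of compound 4 and how far it lies from the others. They also leave open whether a shorter chain, a cyclohexyl ring or a chain ending in an amine or a carboxylic acid on this nitrogen would give a measurable number.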